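Ester tail variation and acyltransferase inhibition

A few compounds are considered here, and "the series" means these few. Any claim that something is new, unique, unknown or untested is made for them only; others in the source may bear on it.

Measured so far:
compound 1 `Cc1cccc(C)c1OC(=O)NC(=O)Oc1c(C)cccc1C`: > 5000 nM
compound 2 `CC(C)c1cccc(C(C)C)c1OC(=O)NC(=O)OCc1ccccc1`: 77 nM
compound 3 `CC(C)c1cccc(C(C)C)c1OC(=O)NC(=O)OCCCc1ccccc1`: 660 nM

In an assay on microsomes from intestine for inhibition of acyl-CoA:cholesterol acyltransferase (Oryctolagus cuniculus) (a lower number here means a stronger inhibitor, a higher number a weaker inhibitor), compound 1 gives > 5000 nM; this is a limit of the assay and not a number, namely (the limit of > 5000 nM in this assay, at which 1 of the 3 values shown sits). In this assay compound 2 gives 77 nM and compound 3 gives 660 nM. Of the two numbers compound 3 stands highest, with compound 2 nearest, separated by the step of an 8.6-fold higher number from compound 2 to compound 3 (0.93 log units; beyond the scatter).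

Compound 4 `CCCCCCCCOC(=O)NC(=O)Oc1c(C(C)C)cccc1C(C)C` differs from compound 3 by pentyl in place of phenyl on a saturated chain carbon, three bonds along the chain from an oxygen next to a carbonyl group. Among the measured compounds shown here, no measured step exchanges a ring for an open chain; the only measured step, an 8.6-fold higher number from compound 2 to compound 3 (0.93 log units; beyond the scatter), concerns chain length alone, so it bears only loosely on this change. For compound 4 the expected step is a 1.1-fold lower number from compound 3 to compound 4 (0.04 log units; within the scatter), not beyond the scatter. The estimate for compound 4 in this assay is 600 nM, within 150 nM to 2500 nM.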

Compound 4, half-maximal inhibitory concentration: 250 nM
For compound 4 the middle estimate is 2.4-fold (0.38 log units) above the measured one; low and high end bracket the measured number.
By their numbers in this assay, from the lowest: compound 2; then compound 4; then compound 3. At a limit, above all of these: compound 1.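

In this assay, an aromatic ring is not needed on this chain: pentyl in place of phenyl gives a 2.6-fold lower number from compound 3 to compound 4 (0.42 log units; beyond the scatter). Even so, the open chain does not match the benzyl tail, with a 3.2-fold higher number from compound 2 to compound 4 (0.51 log units; beyond the scatter). Nothing measured here accounts for either step.

As far as these compounds go, it remains open whether hexyl, the open-chain counterpart of benzyl, would come closer to compound 2. From the compounds shown here alone, the effect of a chain longer than octyl, or of an amine or a carboxylic acid carried on this chain, also remains open.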